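The compounds below may be only part of what the source reports. "The series", "measured", "known", "first", "only" and "open" are said of these compounds alone.

Measured compounds and their numbers:
- compound 1 `CN1CCN(CC(=O)OC2CC3(N(C)C)CC(c4ccccc4)C2C(c2ccccc2)C3)CC1`: 39900 nM
- compound 2 `CN1CCN(CC(=O)NC2CC3(N(C)C)CC(c4ccccc4)C2C(c2ccccc2)C3)CC1`: 66200 nM
- compound 3 `CCN(CC)CC(=O)OC1CC2(N3CCCC3)CC(c3ccccc3)C1C(c1ccccc1)C2`: 49000 nM

In an ADME assay on L6 cells (Rattus norvegicus) for cytotoxicity, read by resazurin assay, with a stated time of 72 h (a lower number here means a stronger inhibitor, a higher number a weaker inhibitor), compound 3 gives 49000 nM, and this number lies within the usual scatter of both compound 1 and compound 2, so the three measured compounds cannot be told apart on cytotoxicity toward these cells. Compound 4 `CCN(CC)CC(=O)OC1CC2(N(C)C)CC(c3ccccc3)C1C(c1ccccc1)C2` is not yet measured. It differs from compound 3 at one spot: dimethylamino in place of pyrrolidin-1-yl on a saturated ring carbon. Going by the values given here, the group that enters is the one that compound 1 and compound 2 already carry on the same ring carbon, while the ester side chain of compound 3 is kept. Among the compounds with values here, only one measured step exists, a 1.7-fold higher number from compound 1 to compound 2 (0.22 log units; within the scatter), and it concerns a different place, the swap of the ester oxygen for an amide nitrogen; that step stayed within the scatter. Within the data shown here, no measured pair shows what happens when the ring amine itself is changed, so the swap of pyrrolidin-1-yl for dimethylamino has no direct precedent here. Since every shown number sits close together, the expected result for compound 4 is a step of a 1.1-fold lower number from compound 3 to compound 4 (0.04 log units; within the scatter), which amounts to no change beyond the scatter. The estimate for compound 4 in this assay is therefore 45000 nM, with a range from 20000 nM to 100000 nM.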

Compound 4, half-maximal inhibitory concentration: 30100 nM
Estimate against measurement, compound 4: 1.5-fold (0.17 log units) above, within the range that was stated.
By their numbers in this assay, from the lowest: compounds 4, 1, 3 and 2 (each within the scatter of the next, the first and the last beyond it).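

In this assay, going by these compounds alone, the first measured change of the amine on this saturated ring carbon, dimethylamino in place of pyrrolidin-1-yl, gives a 1.6-fold lower number from compound 3 to compound 4 (0.21 log units; within the scatter) so opening out the five-membered ring and going from 5 heavy atoms to 3 leaves the number where repeat measurements would put it. On the side chain, diethylamino in place of 4-methylpiperazin-1-yl gives a 1.3-fold lower number from compound 1 to compound 4 (0.12 log units; within the scatter) and this too is no readable change, while exchanging the whole (((4-methylpiperazin-1-yl)methyl)carbonyl)amino group for (((diethylamino)methyl)carbonyl)oxy gives a 2.2-fold lower number from compound 2 to compound 4 (0.34 log units; beyond the scatter) which is the only step among these compounds to pass the scatter, and only modestly. Nothing available here accounts for that small separation.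

That last step changes the linking atom and the side-chain amine together, so an amide carrying the diethylamino side chain on the same core would be needed to tell the two apart. The compounds shown also leave open how this ring carbon would read with a primary amine, a piperidine ring or a longer chain such as dipropylamino.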